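The source may report more compounds than this note shows. Statements on the series, on what has been measured and on what is new or still open speak of the compounds shown alone.

Working notes on the series.

Compound 1 `COc1cc(-c2cc(-c3cc(C(C)C)c(O)cc3C)[nH]c(=O)c2C#N)ccc1O` and compound 2 `Cc1cc(O)c(C(C)C)cc1-c1cc(-c2ccc(N(C)C)cc2)c(C#N)c(=O)[nH]1` share one core and differ only in the aryl group on an aromatic carbon. In a functional assay for inhibition, tested at 100 ug/mL (a lower number here means a weaker effect, a higher number a stronger effect of the compound at the concentration tested), compound 1 gives 44%. In this assay compound 2 gives 68%. Among the compounds with values here, the step of a number 24 percentage points higher from compound 1 to compound 2 (beyond the scatter) is the only measured change, so compound 2 stands highest of the two numbers, with compound 1 as its nearest neighbour.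

Compound 3 `Cc1cc(O)c(C(C)C)cc1-c1cc(-c2ccccc2[N+](=O)[O-])c(C#N)c(=O)[nH]1` is not yet measured. Relative to compound 2 the change is 2-nitrophenyl in place of 4-(dimethylamino)phenyl on an aromatic carbon: the 4-(dimethylamino)phenyl leaves and a 2-nitrophenyl enters, on the same aromatic carbon that was varied between compound 1 and compound 2. That earlier step, a number 24 percentage points higher from compound 1 to compound 2 (beyond the scatter), bears on the question and shows that a change of the aryl group at this carbon can move this assay by a modest amount beyond the scatter. Since compound 2 holds the higher of the two numbers, the step is expected to run downward, estimated as a number 18 percentage points lower from compound 2 to compound 3 (beyond the scatter). For compound 3 the value in this assay is estimated at 50%, within 28% to 72%.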

Compound 3, a percentage reported as inhibition, at one concentration (the size of the read-out at that concentration, not a potency): 37.5%
For compound 3 the middle estimate is 12.5 percentage points above the measured one, within the range that was stated.
By their numbers in this assay, from the lowest: compounds 3 and 1 (each within the scatter of the next); then compound 2.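

In this assay the replacement of 4-(dimethylamino)phenyl by 2-nitrophenyl gives a number 30.5 percentage points lower from compound 2 to compound 3 (beyond the scatter) at this aromatic carbon, ortho to a cyano group and opposite the ring nitrogen, so the aryl group here can move the read-out by a large amount and not only by a modest one. The replacement of 4-hydroxy-3-methoxyphenyl by 2-nitrophenyl gives a number 6.5 percentage points lower from compound 1 to compound 3 (within the scatter) and so separates neither group from the other, which leaves 4-(dimethylamino)phenyl as the only one of the three aryl groups that stands apart, with its steps to both others beyond the scatter. No measurement on hand accounts for the size of either step.

Open, on these data alone, is whether the lower number goes with the nitro group or with its place on the ring, as the step changes both at once; a 4-nitrophenyl or a 2-(dimethylamino)phenyl group would separate the two. Also open, as far as these compounds go, is whether the higher number of compound 2 depends on the dimethylamino group itself or extends to other amines, such as a 4-aminophenyl or 4-(diethylamino)phenyl group.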